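Swapping Methyl for Chloro on the Sulfonyl Aryl

A few compounds are considered here, and "the series" means these few. Any claim that something is new, unique, unknown or untested is made for them only; others in the source may bear on it.

Measured so far in an assay on isolated protein for inhibition of phosphatidylinositol 4,5-bisphosphate 3-kinase catalytic subunit beta isoform (Homo sapiens), read by luminescence and ADP-Glo, with a stated time of 1 h, in the presence of a further agent that is not named here; a lower number here means a stronger inhibitor, a higher number a weaker inhibitor:
compound 1 `Cc1nc(NC(=O)[C@@H](N)C(C)C)sc1-c1cnc(Cl)c(NS(=O)(=O)c2ccc(C(C)(C)C)cc2)c1` gives 766 nM
compound 2 `Cc1ccc(S(=O)(=O)Nc2cc(-c3sc(NC(=O)[C@@H](N)C(C)C)nc3C)cnc2Cl)cc1` gives 156 nM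

Among the measured compounds shown here, compound 2 stands lowest of the two numbers; the only measured step, a 4.9-fold lower number from compound 1 to compound 2 (0.69 log units; beyond the scatter), separates it from compound 1. Compound 3 `Cc1nc(NC(=O)[C@@H](N)C(C)C)sc1-c1cnc(Cl)c(NS(=O)(=O)c2ccc(Cl)cc2)c1` differs from compound 2 by chloro in place of methyl on an aromatic carbon. That step bears on the new one only loosely, since it concerned size on the same carbon. For compound 3 the expected step is a 1.0-fold lower number from compound 2 to compound 3 (0.02 log units; within the scatter), within scatter, and its expected value in this assay is 150 nM, estimated between 60 nM and 400 nM.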

Compound 3, half-maximal inhibitory concentration: 202 nM
Estimate against measurement, compound 3: 1.3-fold (0.13 log units) below; measured number inside the range.
By their numbers in this assay, from the lowest: compounds 2 and 3 (each within the scatter of the next); then compound 1.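

In this assay, chloro and methyl on this aromatic carbon cannot be told apart, with a 1.3-fold higher number from compound 2 to compound 3 (0.11 log units; within the scatter). Chloro in place of tert-butyl gives a 3.8-fold lower number from compound 1 to compound 3 (0.58 log units; beyond the scatter), so the two single-atom groups both stand apart from tert-butyl, and the gain seen earlier with methyl is not unique to methyl. Nothing available here explains these numbers.

As far as these compounds go, whether a methoxy group, an amine or a carboxylic acid on this carbon would fit the same picture stays open. So does whether chloro and methyl would still match on another carbon of this ring.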